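This account rests on a few compounds, and the source may have more. Where it says the series, first, only, none or still open, it means among the compounds named here.

In a functional assay on NCI-H1650 cells (Homo sapiens) for cytotoxicity, read by MTT assay, with a stated time of 48 h (a higher number here means a weaker inhibitor, a lower number a stronger inhibitor), compound 1 `CN(C)CCNc1ccnc2cc(OCc3ccccc3)ccc12` gives 1620 nM, the lowest of the three numbers recorded so far. Among the compounds with values here, its nearest neighbour is compound 2 `Clc1ccnc2cc(OCc3ccccc3)ccc12`, which in this assay gives 2720 nM; the single change from compound 1 to compound 2, chloro in place of (2-(dimethylamino)ethyl)amino on an aromatic carbon, gives a 1.7-fold higher number from compound 1 to compound 2 (0.23 log units; within the scatter). Compound 3 `CCOc1ccc2c(NCCCN(C)C)ccnc2c1` gives 3830 nM in this assay, a number that sits beyond the scatter from compound 1, but compound 3 is not a single-change neighbour of compound 1, so its value does not read as a step.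

Compound 4 `CCCCCCOc1ccc2c(NCCN(C)C)ccnc2c1` differs from compound 1 in one place: pentyl in place of phenyl on a saturated chain carbon bound to an oxygen on an aromatic ring. Within the data shown here, none of the measured steps touches this part of the molecule; the only recorded step, from compound 1 to compound 2, changes the amine substituent, and it stays within the scatter. Among the measured compounds shown here, the data therefore give no step that bears directly on a change at the benzyloxy group. With nothing to point in either direction, compound 4 is expected to show a step of a 1.2-fold higher number from compound 1 to compound 4 (0.09 log units; within the scatter) in this assay, that is, nothing beyond the scatter. The estimate for compound 4 in this assay is 2000 nM, within a range from 800 nM to 5500 nM.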

Compound 4, half-maximal inhibitory concentration: 930 nM
Estimate against measurement, compound 4: 2.2-fold (0.33 log units) above; the measured number falls inside the stated range.
By their numbers in this assay, from the lowest: compounds 4, 1, 2 and 3 (each within the scatter of the next, the first and the last beyond it).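

Within the data shown here, compound 4 gives the first measured step at the benzyloxy group, which the earlier compounds left untouched: in this assay, the change from benzyloxy to hexyloxy gives a 1.7-fold lower number from compound 1 to compound 4 (0.24 log units; within the scatter). For this one pair, therefore, an open pentyl group can stand in place of the phenyl on a saturated chain carbon bound to an oxygen on an aromatic ring without moving the number beyond the scatter, so the aromatic ring of the benzyloxy group is not needed to keep the value in this range. The data offer no measurement that explains why the two compounds read alike.

The compounds shown leave open how far this tolerance reaches, since a single pair cannot show whether a longer chain, an amine or a carboxylic acid in place of the phenyl would also stay within the scatter of compound 1. They also leave open whether the exchange of benzyloxy for hexyloxy would read the same on compound 2, which carries chloro in place of the (2-(dimethylamino)ethyl)amino group.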